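Dichlorophenyl analogue beside three compounds at the assay limit

The source may hold more compounds than are shown below. What is called first, only, known or untested is meant among the compounds shown, and "the series" means these compounds.

Three compounds on a shared core were measured in a functional assay on HT-29 cells (Homo sapiens) for antiproliferative activity, read by MTT assay, with a stated time of 24 h; on this read-out lower numbers stand for stronger inhibition and higher numbers for weaker inhibition:
Compound 1, `COc1ccc(C(=O)/C=C/c2cccc(F)c2)c2c1C=CC(C)(C)O2`, reaches only the limit > 10000 nM.
Compound 2, `COc1ccc(C(=O)/C=C/c2ccc(Br)cc2)c2c1C=CC(C)(C)O2`, reaches only the limit > 10000 nM.
Compound 3, `COc1ccc(C(=O)/C=C/c2ccccc2)c2c1C=CC(C)(C)O2`, reaches only the limit > 10000 nM.

Compound 3 therefore stands at a limit and not at a number, and it shares that position with the other two, as all three sit at the limit of > 10000 nM in this assay, at which 3 of the 3 values shown sit. None of the measured steps can be read: a step that the two limits leave unreadable from compound 1 to compound 2, a step that the two limits leave unreadable from compound 1 to compound 3 and a step that the two limits leave unreadable from compound 2 to compound 3 all lie between two limits, so no change of the aryl group among these compounds has yet produced a readable effect.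

Compound 4, `COc1ccc(C(=O)/C=C/c2ccc(Cl)c(Cl)c2)c2c1C=CC(C)(C)O2`, differs from compound 3 by 3,4-dichlorophenyl in place of phenyl on a double-bonded chain carbon bound to a double-bonded chain carbon. Among the compounds with values here, the measured steps bear on this change only in that every aryl variation so far left the value at the limit, and no step gives a size or a direction in this assay. The step from compound 3 to compound 4 is expected to be a step that the limit leaves unreadable from compound 3 to compound 4. Compound 4 is estimated at 15000 nM, with a range from 4000 nM to 60000 nM, most likely reported again as a limit.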

Compound 4, half-maximal inhibitory concentration: 7580 nM
For compound 4 the middle estimate is 2.0-fold (0.30 log units) above the measured one, within the range that was stated.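

At this place, on a double-bonded chain carbon bound to a double-bonded chain carbon, 3,4-dichlorophenyl gives compound 4 a number in this assay, while the other aryl groups shown stay at a limit: the limit of > 10000 nM in this assay, at which 3 of the 4 values shown sit.

Within the data shown here, this yields the first steps with a direction, an at least 1.3-fold lower number from compound 3 to compound 4 (0.12 log units; that floor lies within the scatter), an at least 1.3-fold lower number from compound 2 to compound 4 (0.12 log units; that floor lies within the scatter) and an at least 1.3-fold lower number from compound 1 to compound 4 (0.12 log units; that floor lies within the scatter), whereas the steps among compound 1, compound 2 and compound 3 still cannot be read. All three new steps are floors only, so they show a lower number without fixing how much lower, and the floors alone do not take compound 4 beyond the scatter.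

On these data alone, whether a phenyl carrying a single chloro would also give a number stays open. So does the outcome with an amine or a carboxylic acid on the aryl ring at this place.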